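Swapping benzyl for methylsulfonyl, with one limit to go on

The source may hold more compounds than are shown below. What is called first, only, known or untested is meant among the compounds shown, and "the series" means these compounds.

Compound 1 `Fc1ccccc1Cc1nc(-c2nc(Cc3ccccc3)n[nH]2)n2ccccc12` offers no starting number: in an in vitro ADME assay on microsomes from liver (Homo sapiens) for metabolic stability (on this read-out lower numbers stand for slow clearance and higher numbers for fast clearance), compound 1 stands as "not determined" (no result reported). Among the compounds with values here, the only other reading comes from a different structure. Compound 2 `Cc1ncc(Cn2nc(-c3nc(C(F)(F)F)n[nH]3)c3cccnc32)cn1` gives < 7 mL.min-1.g-1 in this assay, and this is a limit of the assay, not a number. Compound 3 `CS(=O)(=O)c1n[nH]c(-c2nc(Cc3ccccc3F)c3ccccn23)n1` has yet to be measured. The change methylsulfonyl in place of benzyl on an aromatic carbon puts methylsulfonyl in place of benzyl on an aromatic carbon of a five-membered aromatic ring with 3 nitrogen, and the rest of the structure stays the same. With no number for compound 1, the size of this step cannot be read from the data. A modest step towards slow clearance is expected, a judgement that rests only on compound 2 and its limit of < 7 mL.min-1.g-1. For compound 3 the expected value is 7 mL.min-1.g-1, with an estimated range from 3.5 mL.min-1.g-1 to 18 mL.min-1.g-1.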

Compound 3, intrinsic clearance in microsomes: 11 mL.min-1.g-1
Beside the measured number, compound 3's estimate is 1.6-fold (0.20 log units) below it, within the range that was stated.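

No step can be read from these results: compound 1 has no number in this assay to set against compound 3, and compound 2 differs from compound 3 in more than one place. As far as these compounds go, what swapping benzyl for methylsulfonyl does to clearance stays open. Nothing shown accounts for the value of compound 3.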